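The compounds below may be only part of what the source reports. "The series", "measured", "known", "first", "only" and "open" are said of these compounds alone.

Measured so far in a functional assay on BJAB cells (Homo sapiens) for antiproliferative activity, with a stated time of 4 days; on this read-out higher numbers stand for an effect only at larger amounts of compound and lower numbers for an effect already at smaller amounts:
- compound 1 `CC(=O)Nc1ccc(-c2c(C)nn(-c3nc(-c4ccc(Cl)c(Cl)c4)c(SC(C)C)s3)c2C(=O)O)cc1` gives 139000 nM
- compound 2 `Cc1nn(-c2nc(-c3ccc(Cl)c(Cl)c3)c(SC(C)C)s2)c(C(=O)O)c1-c1ccncc1` gives 5900 nM
- compound 3 `Cc1nn(-c2nc(-c3ccc(Cl)c(Cl)c3)c(SC(C)C)s2)c(C(=O)O)c1-c1cccc(F)c1` gives 900 nM

Compound 1 stands highest of the three in this assay, the one that needs the largest amount for an effect; both other compounds sit well beyond the scatter below it. Compound 4 `Cc1nn(-c2nc(-c3ccc(Cl)c(Cl)c3)c(SC(C)C)s2)c(C(=O)O)c1-c1ccc(Cl)cc1` differs from compound 1 in one place: chloro in place of acetamido on an aromatic carbon. Two measured steps leave the same 4-acetamidophenyl group of compound 1 and both lower the number strongly: a 24-fold lower number from compound 1 to compound 2 (1.37 log units; beyond the scatter) and a 150-fold lower number from compound 1 to compound 3 (2.19 log units; beyond the scatter). A large step downward is therefore expected here as well, roughly a 93-fold lower number from compound 1 to compound 4 (1.97 log units; beyond the scatter). Compound 4 is estimated at 1500 nM in this assay, with a range from 400 nM to 6000 nM.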

Compound 4, half-maximal effective concentration: 2500 nM
Beside the measured number, compound 4's estimate is 1.7-fold (0.22 log units) below it, and the stated range covers the measured number.
By their numbers in this assay, from the lowest: compound 3; then compound 4; then compound 2; then compound 1.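

Across the replacements tried at this position in this assay, the result is consistent: chloro in place of acetamido gives a 56-fold lower number from compound 1 to compound 4 (1.75 log units; beyond the scatter), so a third group without the acetamido also lowers the number strongly. The 4-chlorophenyl group falls in the middle of the replacements, with a 2.8-fold higher number from compound 3 to compound 4 (0.44 log units; beyond the scatter) and a 2.4-fold lower number from compound 2 to compound 4 (0.37 log units; beyond the scatter). Nothing available explains why these groups rank in this order.

Open, on these data alone, is how an amine or a methoxy group would compare with chloro in the same place. Also open, as far as these compounds go, is how 3-chlorophenyl would compare with 4-chlorophenyl, which would separate the effect of the atom from that of its place on the ring.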